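Methoxy in place of hydrogen on compound 1

The source may hold more compounds than are shown below. What is called first, only, known or untested is meant among the compounds shown, and "the series" means these compounds.

Compound 1 `O=C(/C=C/c1ccc2c(c1)B(O)OC2)c1ccccc1` was tested in a toxicity assay on WI-38 cells (Homo sapiens) for cytotoxicity, read by MTT assay, with a stated time of 48 h (on this read-out lower numbers stand for stronger inhibition and higher numbers for weaker inhibition), where compound 1 gives 19100 nM. Among the compounds with values here, this is the only plain number among the two results seen so far; the other result is a limit of the assay. Compound 2 `O=C(/C=C/c1ccc2c(c1)B(O)OC2)c1ccc(OCc2ccccc2)cc1` reaches only that limit, and in this assay compound 2 is reported as > 100000 nM. The measured step of an at least 5.2-fold higher number from compound 1 to compound 2 (0.71 log units; beyond the scatter) therefore points toward weaker inhibition, as far as the limit of > 100000 nM in this assay, at which 1 of the 2 values shown sits, allows it to be read.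

Compound 3 `COc1cccc(C(=O)/C=C/c2ccc3c(c2)B(O)OC3)c1` differs from compound 1 by methoxy in place of hydrogen on an aromatic carbon. Within the data shown here, the only measured step that bears on it is the benzyloxy step, which was at least modest in size. Methoxy is a much smaller group at a different place, so a smaller shift toward weaker inhibition, or none beyond the scatter, is expected for compound 3, namely a 1.3-fold higher number from compound 1 to compound 3 (0.12 log units; within the scatter). The estimate for compound 3 is 25000 nM, between 10000 nM and 80000 nM.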

Compound 3, half-maximal inhibitory concentration: 14600 nM
Estimate against measurement, compound 3: 1.7-fold (0.23 log units) above, within the range that was stated.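

In this assay, methoxy in place of hydrogen, meta to a large group on the six-membered aromatic ring of carbon only, gives a 1.3-fold lower number from compound 1 to compound 3 (0.12 log units; within the scatter). A substituent on this ring, at this place, therefore need not move the number beyond the usual scatter, and compound 3 offers a second plain number alongside compound 1. Compound 2 remains a limit and not a number, and it is the only compound here that points toward weaker inhibition: the limit of > 100000 nM in this assay, at which 1 of the 3 values shown sits.

From the compounds shown here alone, what remains open is whether an amine or a carboxylic acid at this same place would also stay within the scatter. Also open, going by these compounds, is whether methoxy would behave the same way elsewhere on the ring, and how far the number for benzyloxy really lies beyond its limit.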